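Swapping an Epoxide for a Chlorohydrin on Two Chalcones

The compounds below may be only part of what the source reports. "The series", "measured", "known", "first", "only" and "open" are said of these compounds alone.

Compound 1 `COc1ccc(/C=C/C(=O)c2ccc(OCC3CO3)cc2)cc1` and compound 2 `COc1ccc(C(=O)/C=C/c2ccc(OCC3CO3)cc2)cc1` share the same atoms joined differently; the difference between the two cores is not broken down here. In a functional assay on HCT-15 cells (Homo sapiens) for cytotoxicity, read by MTT assay (a higher number here means a weaker inhibitor, a lower number a stronger inhibitor), compound 1 gives 27100 nM, and compound 2 gives 30400 nM; the two numbers lie within the usual scatter of each other.

Compound 3 `COc1ccc(C(=O)/C=C/c2ccc(OCC(O)CCl)cc2)cc1` is compound 2 with one change: 2-chloro-1-hydroxyethyl in place of oxiran-2-yl on a saturated chain carbon bound to an oxygen on an aromatic ring. In this assay compound 3 gives 20600 nM, so the step is a 1.5-fold lower number from compound 2 to compound 3 (0.17 log units; within the scatter).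

Compound 4 `COc1ccc(/C=C/C(=O)c2ccc(OCC(O)CCl)cc2)cc1` carries the same change made on the core of compound 1: 2-chloro-1-hydroxyethyl in place of oxiran-2-yl on a saturated chain carbon bound to an oxygen on an aromatic ring. The place is described in the same words for both pairs, so the change is the same. Because the measured step of a 1.5-fold lower number from compound 2 to compound 3 (0.17 log units; within the scatter) stayed within the scatter, a similarly small step is expected from compound 1 to compound 4, namely a 1.4-fold lower number from compound 1 to compound 4 (0.13 log units; within the scatter). Compound 4 is therefore estimated to give 20000 nM in this assay, with a range from 10000 nM to 40000 nM. This expectation rests on the measured number of compound 1, 27100 nM.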

Compound 4, half-maximal inhibitory concentration: 20500 nM
Compound 4: middle estimate off by 1.0-fold (0.01 log units), on the low side; measured number inside the range.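

In this assay, putting 2-chloro-1-hydroxyethyl in place of oxiran-2-yl gives a 1.3-fold lower number from compound 1 to compound 4 (0.12 log units; within the scatter). Set beside the earlier step, the same change behaves alike on the two cores: the same change on two cores in this assay, a 1.5-fold lower number (0.17 log units; within the scatter) from compound 2 to compound 3 and a 1.3-fold lower number (0.12 log units; within the scatter) from compound 1 to compound 4, 1.1-fold (0.05 log units) apart, within the scatter of two such steps. On these two cores, then, a step measured on one was a fair guide to the step on the other, but the agreement is between two small steps, so it does not show that the change truly moves the number on either core, and two cores cannot speak for the whole series.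

The compounds shown leave open what a different group would do at this place, for example an amine in place of the chlorine of 3-chloro-2-hydroxypropyl, or a longer chain bearing the oxiran-2-yl. They also leave open whether a change that moves the number well beyond the scatter would carry from one core to the other as closely as this one did.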